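Returning the 1-phenylethyl group to the urea nitrogen

The source may report more compounds than this note shows. Statements on the series, on what has been measured and on what is new or still open speak of the compounds shown alone.

Three related compounds sharing one core have been tested in an assay on membranes from Sf9 cells for displacement of a labelled ligand from histamine H2 receptor (Homo sapiens), read by scintillation counting, with a stated time of 60 min; on this read-out lower numbers stand for stronger inhibition and higher numbers for weaker inhibition. Compound 1 `Cc1nc(N)sc1CCCN/C(N)=N/C(=O)N[C@H](C)c1ccccc1` gives 17.8 nM, compound 2 `Cc1nc(N)sc1CCCN/C(N)=N/C(=O)NCC(C)CCc1ccccc1` gives 63.1 nM, and compound 3 `CCCNC(=O)/N=C(\N)NCCCc1sc(N)nc1C` gives 105 nM. Compound 3 therefore stands at the highest number of the three: its gap to compound 2 lies within the scatter, while the step of a 5.9-fold higher number from compound 1 to compound 3 (0.77 log units; beyond the scatter) is beyond it.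

Compound 4 `Cc1nc(N)sc1CCCN/C(N)=N/C(=O)N[C@@H](C)c1ccccc1` is the next structure to be measured. Relative to compound 3 the change is 1-phenylethyl in place of propyl on an amide-type nitrogen. Compound 4 thus carries the same group as compound 1, but in the mirror-image form at its stereocentre. For the measured compounds named here, the one measured step that bears directly on this change is a 5.9-fold higher number from compound 1 to compound 3 (0.77 log units; beyond the scatter), which points to a lower number when 1-phenylethyl replaces propyl. How much of that gain depends on the configuration at the stereocentre is not known from these compounds. Compound 4 is therefore expected to give 40 nM in this assay, within a range of 10 nM to 160 nM, an estimated step of a 2.6-fold lower number from compound 3 to compound 4 (0.42 log units; beyond the scatter).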

Compound 4, inhibition constant: 51.3 nM
Estimate against measurement, compound 4: 1.3-fold (0.11 log units) below; the measured number falls inside the stated range.
By their numbers in this assay, from the lowest: compound 1; then compounds 4, 2 and 3 (each within the scatter of the next, the first and the last beyond it).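

On the amide-type nitrogen, 1-phenylethyl keeps an advantage over propyl even in the configuration of compound 4, with a 2.0-fold lower number from compound 3 to compound 4 (0.31 log units; beyond the scatter). The configuration at the stereocentre also matters in this assay: the form drawn R gives the lower number, with a 2.9-fold higher number from compound 1 to compound 4 (0.46 log units; beyond the scatter). This second step can be assigned to the stereocentre alone: the fact that compounds 1 and 4 differ only in the configuration as drawn

As far as these compounds go, what remains open is how much of the advantage over propyl comes from the phenyl ring and how much from the branching methyl carbon at the stereocentre. A benzyl group on the same nitrogen would carry the ring without the stereocentre, and a 1-cyclohexylethyl group would carry the stereocentre without the aromatic ring, so either could help separate the two contributions.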